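The source may hold more compounds than are shown below. What is called first, only, known or untested is meant among the compounds shown, and "the series" means these compounds.

Compound 1, with the structure `CCCCC(CCO)n1cnc2c(Cl)ncnc21`, is the starting point. In a functional assay on HCT-116 cells (Homo sapiens) for antiproliferative activity, read by MTT assay, with a stated time of 48 h (a lower number here means a stronger inhibitor, a higher number a weaker inhibitor), compound 1 gives > 50000 nM, which is a limit of the assay rather than a number. For the measured compounds named here, its one measured neighbour, compound 2, has the structure `CCCCC(CCO)n1cnc2c(N)ncnc21`. In this assay compound 2 also gives > 50000 nM, again a limit and not a number. The step from one to the other, amino in place of chloro on an aromatic carbon, is a step that the two limits leave unreadable from compound 1 to compound 2, so nothing of its size can be read, because of the limit of > 50000 nM in this assay, at which 2 of the 2 values shown sit. Going by the values given here, compound 1 therefore stands only at a limit, with no measured step of readable size beside it.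

Compound 3 has the structure `CCCCCCCCC(CCO)n1cnc2c(Cl)ncnc21`. The change from compound 1 is butyl in place of hydrogen on a saturated chain carbon, five bonds along the chain from an aromatic nitrogen. Among the compounds with values here, no measured step bears on this change, and the only step recorded is unreadable. With compound 1 at a limit, the expected step is a number no higher from compound 1 to compound 3 (the limit leaves the size open), meaning no readable change in either direction. Compound 3 is thus estimated at 50000 nM, within a range from 15000 nM to 200000 nM, most likely reported again as a limit.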

Compound 3, half-maximal inhibitory concentration: 1650 nM
Compound 3: the middle estimate sits 30-fold (1.48 log units) above what was measured; measured number below the stated range.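

In this assay, butyl in place of hydrogen on a saturated chain carbon, five bonds along the chain from an aromatic nitrogen, is an at least 30-fold lower number from compound 1 to compound 3 (1.48 log units; beyond the scatter), so this position on the chain can move the read-out from the limit of the assay to a real number. Compound 1 gives > 50000 nM, which is a limit and not a number, so the true size of the step may be larger than the figure printed with it. Compound 3 is thus the first compound here with a measured potency, whereas the step from chloro to amino on the aromatic carbon cannot be read: the limit of > 50000 nM in this assay, at which 2 of the 3 values shown sit.

With only one chain extension shown, it remains open whether potency keeps improving with a chain longer than that of compound 3, or whether a chain ending in an amine or a carboxylic acid would behave the same way. It is also open whether amino in place of chloro on the aromatic carbon would change the number once the chain carries the extra butyl, as the amino compound shown has the shorter chain.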